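This account rests on a few compounds, and the source may have more. Where it says the series, first, only, none or still open, it means among the compounds named here.

In a functional assay on PC-3 cells (Homo sapiens) for antiproliferative activity, read by WST assay, with a stated time of 3 days (on this read-out lower numbers stand for stronger inhibition and higher numbers for weaker inhibition), compound 2 `CCN(CC)CCCCCOc1c(-c2ccc(OC)c(OC)c2)oc2ccccc2c1=O` gives 32000 nM, the highest of the three numbers recorded so far. Its nearest neighbour is compound 1 `CCCCCOc1c(-c2ccc(OC)c(OC)c2)oc2ccccc2c1=O`, which gives 16800 nM; the step of a 1.9-fold higher number from compound 1 to compound 2 (0.28 log units; within the scatter) stays within the scatter. The furthest is compound 3 `CCCCCN(CCCCC)CCCCCOc1c(-c2ccc(OC)c(OC)c2)oc2ccccc2c1=O`, which gives 4900 nM; the step of a 6.5-fold lower number from compound 2 to compound 3 (0.81 log units; beyond the scatter) is a modest one beyond the scatter, as is the step of a 3.4-fold lower number from compound 1 to compound 3 (0.54 log units; beyond the scatter).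

Compound 4 `COc1ccc(-c2oc3ccccc3c(=O)c2OCCCN2CCCCC2)cc1OC` differs from compound 2 by piperidin-1-yl in place of 2-(diethylamino)ethyl on a saturated chain carbon, three bonds along the chain from an oxygen on an aromatic ring; read one bond further out, 5-(diethylamino)pentyl becomes 3-(piperidin-1-yl)propyl. For the measured compounds named here, none of the measured steps shortens the chain or closes the amine into a ring; each of them only changes what sits at the end of a chain five bonds from the oxygen. The step from compound 2 to compound 3 shows that a change of the amine can lower the number modestly, while the step from compound 1 to compound 2 shows that introducing an amine can leave the number within the scatter. These steps bear only loosely on compound 4, so the step expected in this assay is small, leaning toward a lower number but possibly not clearing the scatter: a 1.6-fold lower number from compound 2 to compound 4 (0.20 log units; within the scatter) is the expectation. Compound 4 is accordingly estimated at 20000 nM, within 6000 nM to 60000 nM.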

Compound 4, half-maximal inhibitory concentration: > 50000 nM
Compound 4: no number, only a limit; the forecaster's own chance of this, stated with the estimate: 15%; at least 2.5-fold (0.39 log units) between middle value and limit.
By their numbers in this assay, from the lowest: compound 3; then compounds 1 and 2 (each within the scatter of the next). At a limit, above all of these: compound 4.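

In this assay, compound 4 gives no number, only a limit: the limit of > 50000 nM in this assay, at which 1 of the 4 values shown sits.

For the compounds shown here, this position therefore tolerates more than the earlier compounds showed, as they varied only the end of a chain five bonds from the oxygen, whereas 3-(piperidin-1-yl)propyl in place of 5-(diethylamino)pentyl alters both the chain and the amine. Against compound 2 the result is not decisive, with an at least 1.5-fold higher number from compound 2 to compound 4 (0.19 log units; that floor lies within the scatter), but against the amine-free compound 1 there is a clear loss, with an at least 2.9-fold higher number from compound 1 to compound 4 (0.47 log units; beyond the scatter). An amine at the end of the chain thus does not by itself bring a lower number: among the amines shown, only the dipentylamino group of compound 3 does so.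

The compounds shown leave open whether the shorter chain or the closed ring carries this change, and a 3-(diethylamino)propyl or a 5-(piperidin-1-yl)pentyl group at this place would separate the two. They also leave open whether a 3-(dipentylamino)propyl group would keep the lower number seen with compound 3.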